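A few compounds are considered here, and "the series" means these few. Any claim that something is new, unique, unknown or untested is made for them only; others in the source may bear on it.

Compound 2 `Clc1ccc(-c2cc(-c3ccco3)cc(-c3ccc(Cl)s3)n2)cc1` gives 53.1% in an assay on isolated protein for inhibition of DNA topoisomerase 1 (Homo sapiens), with a stated time of 30 min, tested at 100 uM (on this read-out lower numbers stand for less inhibition and higher numbers for more inhibition at the one concentration tested (going by the name of the read-out)), the highest of the three numbers in hand. Compound 1 `Cc1ccsc1-c1cc(-c2ccco2)cc(-c2ccc(Cl)cc2)n1` gives 1%, and compound 3 `Cc1cccc(-c2cc(-c3ccoc3)cc(-c3ccc(Cl)s3)n2)c1` gives 2.6%. For the measured compounds named here, the one single-point step measured so far, a number 52.1 percentage points higher from compound 1 to compound 2 (beyond the scatter), concerns the thiophene group and not the furan.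

Compound 4 `Clc1ccc(-c2cc(-c3ccc(Cl)o3)cc(-c3ccc(Cl)s3)n2)cc1` differs from compound 2 by chloro in place of hydrogen on an aromatic carbon, that is furan-2-yl to 5-chlorofuran-2-yl. Going by the values given here, no measured step touches the furan, so nothing supports a step beyond the scatter in either direction for this assay. The estimate for compound 4 is therefore held near compound 2, at 53% within 25% to 78%, and the expected step is a number 0.1 percentage points lower from compound 2 to compound 4 (within the scatter), with wide uncertainty given the thin data.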

Compound 4, a percentage reported as inhibition, at one concentration (the size of the read-out at that concentration, not a potency): 2.2%
Estimate against measurement, compound 4: 50.8 percentage points above, outside the stated range (below it).
By their numbers in this assay, from the lowest: compounds 1, 4 and 3 (each within the scatter of the next); then compound 2.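

In this assay, the furan position proves sensitive: furan-2-yl to 5-chlorofuran-2-yl gives a number 50.9 percentage points lower from compound 2 to compound 4 (beyond the scatter), so one chloro on the aromatic carbon next to the ring oxygen is enough to produce a large step. Compound 2 therefore responds to change at the furan as well as at the thiophene group, where the earlier step was a number 52.1 percentage points higher from compound 1 to compound 2 (beyond the scatter). Nothing available bears on the reason for the new step.

As far as these compounds go, whether the same drop would follow with fluoro, methyl, an amine or a carboxylic acid at this carbon remains open. Also open, from the compounds shown here alone, is whether the step depends on the rest of compound 2.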